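Ethoxy to propoxy on compound 2

The compounds below may be only part of what the source reports. "The series", "measured", "known", "first", "only" and "open" are said of these compounds alone.

Among the measured compounds shown here, in an ADME assay on LLC-PK1 cells (Sus scrofa) for permeability (a lower number here means that the compound crosses the layer more slowly, a higher number that the compound crosses the layer faster), compound 1 `C[C@]1(c2cc(NC(=O)c3ccc(Cl)cn3)cc(F)c2F)N=C(N)S[C@@]2(C#N)C[C@H]21` gives 39 10^-6 cm/s and compound 2 `CCOc1cnc(C(=O)Nc2cc(F)c(F)c([C@@]3(C)N=C(N)S[C@@]4(COC)C[C@H]43)c2)cn1` gives 25 10^-6 cm/s as the only two numbers so far. These values lie within the scatter of each other, so compound 2 cannot be told apart from compound 1 on this evidence. Compound 3 `CCCOc1cnc(C(=O)Nc2cc(F)c(F)c([C@@]3(C)N=C(N)S[C@@]4(COC)C[C@H]43)c2)cn1` has no number yet. The change methyl in place of hydrogen on a saturated chain carbon, two bonds along the chain from an oxygen on an aromatic ring puts methyl in place of hydrogen on a saturated chain carbon, two bonds along the chain from an oxygen on an aromatic ring, turning ethoxy into propoxy. For the measured compounds named here, no measured pair shows a change of this kind, so no direct guide exists. No step beyond the scatter is expected in this assay and no direction is favoured. The estimated 1.0-fold lower number from compound 2 to compound 3 (0.02 log units; within the scatter) stays within the scatter. Compound 3 is expected at 24 10^-6 cm/s with an estimated range from 13 10^-6 cm/s to 38 10^-6 cm/s for now.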

Compound 3, apparent permeability: 18 10^-6 cm/s
Compound 3: middle estimate off by 1.3-fold (0.12 log units), on the high side; the range from low to high includes it.
By their numbers in this assay, from the lowest: compounds 3, 2 and 1 (each within the scatter of the next, the first and the last beyond it).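

In this assay the series now has its first step between compounds that differ in one place: a 1.4-fold lower number from compound 2 to compound 3 (0.14 log units; within the scatter). At this position, methyl in place of hydrogen, which turns ethoxy into propoxy, therefore gives no difference that can be told from the scatter, though this rests on a single pair. No measurement of any other kind bears on this result.

Whether a longer chain such as butoxy, a branched group such as isopropoxy, or an amine at the end of the chain would also remain within the scatter is open. So is whether the same methyl would read alike on a compound that differs elsewhere in the structure.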